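The compounds below may be only part of what the source reports. "The series", "measured", "known", "first", "only" and "open" are said of these compounds alone.

In a functional assay on DU-145 cells (Homo sapiens) for inhibition, read by trypan blue exclusion, with a stated time of 96 h (a higher number here means a weaker inhibitor of growth, a lower number a stronger inhibitor of growth), three compounds have been measured. Compound 1 `Cc1ccc(S/C(=C/c2ccc(F)cc2F)C(=O)c2ccc(Br)cc2)cc1` gives only a limit of the assay, > 100000 nM. Compound 2 `Cc1ccc(S/C(=C/c2ccc(N(C)C)cc2)C(=O)c2ccc(Br)cc2)cc1` likewise gives only a limit, > 100000 nM. The step that the two limits leave unreadable from compound 1 to compound 2 therefore cannot be read. For the measured compounds named here, compound 3 `COc1ccccc1/C=C(/SCc1ccc(Cl)cc1)C(=O)c1ccc(Br)cc1` is the one compound with a number: in this assay compound 3 gives 1000 nM. Going by the values given here, compound 3 thus stands alone as the only measured value. Compound 1 and compound 2 sit at the limit (the limit of > 100000 nM in this assay, at which 2 of the 3 values shown sit).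

Compound 4 `COc1ccccc1/C=C(/Sc1ccc(C)cc1)C(=O)c1ccc(Br)cc1` differs from compound 3 in one place: 4-methylphenyl in place of 4-chlorobenzyl on a sulfur. Among the compounds with values here, no measured step follows this change, so nothing shows how large its effect is or in which direction. Compound 1 and compound 2 both carry the 4-methylphenyl on the sulfur that enters here, though each also carries a different group on the chain carbon than compound 3 does. Because compound 1 and compound 2, with that same group on the sulfur, sit at the limit (the limit of > 100000 nM in this assay, at which 2 of the 3 values shown sit), compound 4 is expected to inhibit growth more weakly, the expected step being a 20-fold higher number from compound 3 to compound 4 (1.30 log units; beyond the scatter). For compound 4 the estimate in this assay is 20000 nM, within a range from 3000 nM to 100000 nM.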

Compound 4, concentration for 50% growth inhibition: 9000 nM
For compound 4 the middle estimate is 2.2-fold (0.35 log units) above the measured one, within the range that was stated.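

On a sulfur, 4-methylphenyl in place of 4-chlorobenzyl gives a 9.0-fold higher number from compound 3 to compound 4 (0.95 log units; beyond the scatter), so this position affects growth inhibition, yet this group does not by itself take a compound to the limit. With that group held fixed, 2-methoxyphenyl on the double-bonded chain carbon gives an at least 11-fold lower number from compound 2 to compound 4 (1.04 log units; beyond the scatter), and the same group gives an at least 11-fold lower number from compound 1 to compound 4 (1.04 log units; beyond the scatter), the first readable sign that this second position matters too. Compound 1 and compound 2 each give only a limit of the assay, so these two steps are minimum sizes: the limit of > 100000 nM in this assay, at which 2 of the 4 values shown sit.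

The change on the sulfur swaps chlorine for methyl and also removes the carbon linking the ring to the sulfur, and 4-chlorophenyl or 4-methylbenzyl there would separate these two differences. As far as these compounds go, how an amine or a longer chain on the sulfur would read in this assay also remains open.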